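The source may hold more compounds than are shown below. What is called first, only, known or untested is meant among the compounds shown, and "the series" means these compounds.

Measured compounds in an ADME assay on RAW264.7 cells (Mus musculus) for cytotoxicity, read by WST assay; on this read-out lower numbers stand for higher toxicity in this test and higher numbers for lower toxicity in this test:
- compound 1 `O=C(NCc1ccco1)c1ccc(CN2C(=O)c3ccccc3S2(=O)=O)cc1` gives > 100000 nM, which is a limit of the assay and not a number.
- compound 2 `O=C(NCc1ccco1)c1ccc(CN2Cc3ccccc3C2=O)cc1` gives > 100000 nM, again a limit.
- compound 3 `O=C(NCc1ccco1)c1ccc(Cn2sc3ccccc3c2=O)cc1` gives > 100000 nM, again a limit.

Going by the values given here, all three sit at the limit of > 100000 nM in this assay, at which 3 of the 3 values shown sit, so no compound in the set shows measurable toxicity in this assay, and no step between measured compounds can be sized. Compound 1 therefore stands at the limit, indistinguishable from compound 2 and compound 3 on the numbers shown.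

The unmeasured compound 4 `CC(C)(C)OC(=O)NC(=O)c1ccc(CN2C(=O)c3ccccc3S2(=O)=O)cc1` keeps the core of compound 1 and differs by tert-butoxycarbonyl in place of (furan-2-yl)methyl on an amide-type nitrogen. Nothing measured bears on this change, since every value in the set is a limit. The expectation for compound 4 is therefore no step beyond the scatter, with a number no higher from compound 1 to compound 4 (the limit leaves the size open) reflecting a compound that is most likely reported again as a limit in this assay. Compound 4 is estimated at 100000 nM, within 40000 nM to 250000 nM.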

Compound 4, concentration lethal to 50% of the cells: > 100000 nM
Compound 4 was reported as a limit; the forecaster's own chance of this, stated with the estimate: 80%; the middle value sits exactly at the limit.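

In this assay compound 4 gives > 100000 nM, a limit and not a number. Going by these compounds alone, compound 1 also stands at a limit, so no step between compound 1 and compound 4 can be read. The compounds shown leave open which change in the series, if any, would give a measurable value.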